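Shortening the Amine Chain of Compound 3

The source may hold more compounds than are shown below. What is called first, only, known or untested is meant among the compounds shown, and "the series" means these compounds.

Of the compounds shown here, three sharing one core have been measured in a functional assay on MCF7 cells (Homo sapiens) for antiproliferative activity, with a stated time of 72 h; a lower number here means a stronger inhibitor, a higher number a weaker inhibitor. Compound 1 `COC(=O)CN(C)Cc1c(OC)cc(OC)c(C(=O)/C=C/c2ccccc2Cl)c1O` gives 10600 nM, compound 2 `COc1cc(OC)c(C(=O)/C=C/c2ccccc2Cl)c(O)c1CN1CCCCC1` gives 2600 nM, and compound 3 `COc1cc(OC)c(C(=O)/C=C/c2ccccc2Cl)c(O)c1CN(C)CCCN(C)C` gives 3200 nM. Compound 3 therefore sits level with compound 2, and clearly below compound 1, which has the highest number of the three.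

Compound 4 `COc1cc(OC)c(C(=O)/C=C/c2ccccc2Cl)c(O)c1CN(C)C` differs from compound 3 by hydrogen in place of 2-(dimethylamino)ethyl on a saturated chain carbon bound to an amine nitrogen. In words, hydrogen stands in place of 2-(dimethylamino)ethyl on a saturated chain carbon bound to an amine nitrogen, so (3-(dimethylamino)propyl)(methyl)amino becomes dimethylamino.

Within the data shown here, no measured step makes exactly this change, so the guidance is indirect. The closest guide is a 1.2-fold higher number from compound 2 to compound 3 (0.09 log units; within the scatter), where exchanging one amine group for another left the number within the scatter. Two modest steps, a 4.1-fold lower number from compound 1 to compound 2 (0.61 log units; beyond the scatter) and a 3.3-fold lower number from compound 1 to compound 3 (0.52 log units; beyond the scatter), both remove a methoxycarbonyl group, which is absent from compound 4 and so offers no reason to expect a similar shift. No step beyond the scatter is therefore expected in this assay. The expected change is a 1.1-fold lower number from compound 3 to compound 4 (0.03 log units; within the scatter). Compound 4 is estimated at 3000 nM, with an expected range of 1200 nM to 8000 nM.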

Compound 4, half-maximal inhibitory concentration: 90 nM
Beside the measured number, compound 4's estimate is 33-fold (1.52 log units) above it, outside the stated range (below it).
By their numbers in this assay, from the lowest: compound 4; then compounds 2 and 3 (each within the scatter of the next); then compound 1.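

Among these compounds, the amine on this saturated chain carbon matters far more in this assay than the earlier compounds suggested: replacing 2-(dimethylamino)ethyl with hydrogen gives a large step (a 36-fold lower number from compound 3 to compound 4 (1.55 log units; beyond the scatter)), whereas exchanging piperidin-1-yl for (3-(dimethylamino)propyl)(methyl)amino had changed almost nothing (a 1.2-fold higher number from compound 2 to compound 3 (0.09 log units; within the scatter)). Dimethylamino also stands well clear of the other two amine groups, with large steps from the piperidin-1-yl compound (a 29-fold lower number from compound 2 to compound 4 (1.46 log units; beyond the scatter)) and from the compound carrying ((methoxycarbonyl)methyl)(methyl)amino (a 120-fold lower number from compound 1 to compound 4 (2.07 log units; beyond the scatter)), which makes compound 4 the strongest inhibitor of the four. The effect is therefore not a gradual one across these compounds, since compounds 2 and 3 remain level despite their very different amine groups, and no measurement is available to explain the sharp change.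

On these data alone, it remains open whether this low number is special to dimethylamino or is shared by other small amines, such as methylamino, diethylamino or pyrrolidin-1-yl. A chain of intermediate length, such as (2-(dimethylamino)ethyl)(methyl)amino, would show whether the number falls steadily as the chain shortens or only once the chain is gone.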